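The source may report more compounds than this note shows. Statements on the series, on what has been measured and on what is new or still open speak of the compounds shown alone.

Compound 1, `C/C(=N\NC(=O)COc1cccc2ccccc12)c1cccc([N+](=O)[O-])c1`, is tested in an ADME assay on HEL cells (Homo sapiens) for cytotoxicity (a higher number here means that more compound is tolerated, a lower number that less compound is tolerated), and gives 20 ug/mL. Compound 2, `C/C(=N\NC(=O)COc1cccc2ccccc12)c1ccc(C#N)cc1Br`, gives 20 ug/mL in this assay. The step of no change at the digits printed from compound 1 to compound 2 (within the scatter) is within the scatter, so compound 2 stands level with compound 1 at the digits shown, and compound 1 is its nearest neighbour among the measured values. Compound 3, `O=C(COc1cccc2ccccc12)N/N=C/c1ccccc1Br`, in this assay gives only a limit, >= 20 ug/mL, and not a number. Of the three values shown, one sits at the limit of >= 20 ug/mL in this assay, at which 1 of the 3 values shown sits.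

Compound 4, `C/C(=N\NC(=O)COc1cccc2ccccc12)c1ccccc1`, has not yet been measured in this assay. It differs from compound 2 in one place: phenyl in place of 2-bromo-4-cyanophenyl on a carbon with a double bond to nitrogen. Going by the values given here, the only measured step that bears on this change is the one from compound 1 to compound 2, where an aryl group on the same carbon with a double bond to nitrogen was exchanged and the value did not move beyond the scatter. A second exchange of the aryl group at the same place is therefore expected to give a step of no change at the digits printed from compound 2 to compound 4 (within the scatter), that is, none beyond the scatter, in either direction. Compound 4 is accordingly estimated at 20 ug/mL, with a range from 10 ug/mL to 40 ug/mL.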

Compound 4, minimum cytotoxic concentration: 20 ug/mL
For compound 4 middle estimate and measured number coincide at the digits printed, and the stated range covers the measured number.
By their numbers in this assay, from the lowest: compounds 1, 2 and 4 (each within the scatter of the next).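

Exchanging 2-bromo-4-cyanophenyl for phenyl on this carbon with a double bond to nitrogen gives no change at the digits printed from compound 2 to compound 4 (within the scatter) in this assay, so the aryl group here needs neither the bromine nor the nitrile to keep the reading at the same level. Hydrogen in place of nitro on an aromatic carbon likewise gives no change at the digits printed from compound 1 to compound 4 (within the scatter), which adds what the earlier exchange of one substituted aryl group for another could not show: the unsubstituted phenyl reads level with both substituted compounds. One caution attaches to this flat picture, as not every reading in the series is a number: the limit of >= 20 ug/mL in this assay, at which 1 of the 4 values shown sits.

The compounds shown leave open whether an amine or a carboxylic acid on the phenyl ring would move the value in this assay, as every group seen at this place so far leaves it level. They also leave open whether a longer chain in place of the saturated chain carbon, or any change to the shared core, would alter how much compound is tolerated.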